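Trifluoroethyl to ethyl: outlook for compound 4

The compounds below may be only part of what the source reports. "The series", "measured", "known", "first", "only" and "open" are said of these compounds alone.

Compound 2 `O=C(OCC(F)(F)F)c1ccsc1NC(=O)[C@@H]1CCCN1` carries a 2,2,2-trifluoroethoxy group on the shared core. In a toxicity assay on HUVEC cells (Homo sapiens) for inhibition (on this read-out higher numbers stand for weaker inhibition of growth and lower numbers for stronger inhibition of growth), compound 2 gives only a limit, > 250 ug/mL, and not a number. Within the data shown here, its nearest measured relative is compound 1 `O=C1CC[C@@H](COC(=O)c2ccsc2NC(=O)[C@@H]2CCCN2)N1`, which in this assay gives 88.6 ug/mL; the one recorded step to it, an at least 2.8-fold higher number from compound 1 to compound 2 (0.45 log units; beyond the scatter), is the only measured step that touches the same place on the chain. Compound 3 `COC(=O)c1sccc1NC(=O)[C@@H]1CCCN1` gives 91.4 ug/mL in this assay.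

Compound 4 `CCOC(=O)c1ccsc1NC(=O)[C@@H]1CCCN1` is the next member: methyl in place of trifluoromethyl on a saturated chain carbon bound to an oxygen next to a carbonyl group. Among the measured compounds shown here, no measured step covers this exact exchange. The step from compound 1 to compound 2 shows that the trifluoroethoxy compound sits at the top of the measured range; removing the fluorines is expected to bring the number back toward the values of compound 1 and compound 3, which lie close to each other.

The step from compound 2 to compound 4 in this assay is therefore expected to be a drop to a lower number, roughly an at least 2.2-fold lower number from compound 2 to compound 4 (0.35 log units; beyond the scatter). Compound 4 is expected to give about 110 ug/mL, plausibly between 50 ug/mL and 250 ug/mL.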

Compound 4, concentration for 50% growth inhibition: > 250 ug/mL
Compound 4: only a limit was reported (the forecaster's own chance of this, stated with the estimate: 25%); at least 2.2-fold (0.35 log units) between middle value and limit.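

In this assay, the change from trifluoromethyl to methyl on the saturated chain carbon leaves the read-out at a limit, so a reading at that limit does not depend on the fluorines: compound 4, like compound 2, gives a limit and not a number. Methyl in place of 5-oxopyrrolidin-2-yl gives an at least 2.8-fold higher number from compound 1 to compound 4 (0.45 log units; beyond the scatter), which reads the same as the step with trifluoromethyl in that place, an at least 2.8-fold higher number from compound 1 to compound 2 (0.45 log units; beyond the scatter); both small groups therefore separate from compound 1 in the same direction, and this no longer rests on a single fluorinated example. The step between the two small groups cannot be read, and no size can be given to the fluorine exchange, because both compounds stand at the same limit: the limit of > 250 ug/mL in this assay, at which 2 of the 4 values shown sit.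

Going by these compounds, how far compound 2 and compound 4 lie past that limit, and whether they differ from each other at all, stays open. Also open, on these data alone, is whether a longer chain, an amine or a carboxylic acid at this place would stay at the limit or return to a number near that of compound 1.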